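Salicylanilide series: pyridinyl replaced by fluoro on the acid ring

This account rests on a few compounds, and the source may have more. Where it says the series, first, only, none or still open, it means among the compounds named here.

Measured in a functional assay on KG-1 cells (Homo sapiens) for cytotoxicity, read by luminescence and CellTiter-Glo, with a stated time of 3 days; on this read-out lower numbers stand for stronger inhibition and higher numbers for weaker inhibition:
compound 1 `O=C(Nc1cc(C(F)(F)F)cc(C(F)(F)F)c1)c1ccc(Cl)cc1O` gives 620 nM
compound 2 `O=C(Nc1ccc(Br)c(Cl)c1)c1cc(F)ccc1O` gives 670 nM
compound 3 `N#Cc1ccc(NC(=O)c2cc(-c3ccncc3)ccc2O)cc1` gives 7990 nM

Compound 3 stands highest of the three numbers; compound 2 and compound 1 both sit well below it, beyond the scatter. Compound 4 `N#Cc1ccc(NC(=O)c2cc(F)ccc2O)cc1` differs from compound 3 in one place: fluoro in place of pyridin-4-yl on an aromatic carbon. Within the data shown here, no measured pair shows this exact change. Compound 2 carries fluoro on its acid ring and gives 670 nM, while compound 3 with pyridin-4-yl gives 7990 nM, though the two also differ in the amide part. On that basis a step down in this assay is expected, beyond the scatter, the value for compound 4 estimated at 2000 nM (range 700 nM to 6000 nM), an expected step of a 4.0-fold lower number from compound 3 to compound 4 (0.60 log units; beyond the scatter).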

Compound 4, half-maximal inhibitory concentration: 2670 nM
Compound 4: the middle estimate sits 1.3-fold (0.13 log units) below what was measured; low and high end bracket the measured number.
By their numbers in this assay, from the lowest: compounds 1 and 2 (each within the scatter of the next); then compound 4; then compound 3.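

Among these compounds, replacing pyridin-4-yl with fluoro, with the rest of the structure unchanged, gives the first single-place comparison: in this assay it produces a 3.0-fold lower number from compound 3 to compound 4 (0.48 log units; beyond the scatter). At this position, para to a hydroxy group, the six-membered aromatic ring is therefore not needed to reach the lower number, and the much smaller fluoro serves better. Nothing available explains the step.

As far as these compounds go, whether a phenyl, a methoxy or an amine at this position would give a similar number remains open. From the compounds shown here alone, it is also open whether the same change gives a similar step with other amide parts.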